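The compounds below may be only part of what the source reports. "The series", "measured", "known", "first", "only" and "open" are said of these compounds alone.

Compound 1 `COC(=O)CCCNC(=O)CN1CN(c2ccccc2)C2(CCN(C(=O)c3ccc(C(C)(C)C)cc3)CC2)C1=O` and compound 2 `CCOC(=O)C1CCN(C(=O)CN2CN(c3ccccc3)C3(CCN(C(=O)c4ccc(C(C)(C)C)cc4)CC3)C2=O)CC1` share one core and differ in a single end group. In an assay on HEK293 cells for displacement of a labelled ligand from NPC1-like intracellular cholesterol transporter 1 (Homo sapiens) (a lower number here means a stronger inhibitor, a higher number a weaker inhibitor), compound 1 gives "not determined" (no result reported). In this assay, within the data shown here, compound 2 gives 3100 nM, and as this is the only number in the set, compound 2 stands alone with nothing to rank against. Compound 3 `CC(C)(C)c1ccc(C(=O)N2CCC3(CC2)C(=O)N(CC(=O)NCCCCN)CN3c2ccccc2)cc1` keeps the core of compound 2 and differs in one place: (4-aminobutyl)amino in place of 4-(ethoxycarbonyl)piperidin-1-yl on a carbonyl carbon. Among the measured compounds shown here, no pair of measured compounds shows what such an exchange does, so the direction of the step cannot be read from the data. The expected step in this assay is a 1.1-fold higher number from compound 2 to compound 3 (0.05 log units; within the scatter), which would be small and within the usual scatter. Compound 3 is therefore expected to give 3500 nM in this assay, with a range from 900 nM to 14000 nM.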

Compound 3, half-maximal inhibitory concentration: 14500 nM
Compound 3: middle estimate off by 4.1-fold (0.62 log units), on the low side; measured number above the stated range.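

This position on the carbonyl carbon responds to the group it carries: in this assay, putting (4-aminobutyl)amino in place of 4-(ethoxycarbonyl)piperidin-1-yl gives a 4.7-fold higher number from compound 2 to compound 3 (0.67 log units; beyond the scatter), which means a weaker inhibitor. The exchange changes several things at once, replacing a six-membered ring and its ester with an open chain that has no ring and ends in an amine, so this single step cannot be assigned to any one of those features. Nothing available here explains the step.

As far as these compounds go, it remains open whether losing the ring, losing the ester or adding the terminal amine matters most. A plain piperidin-1-yl group would test the ester, while a butylamino chain without the terminal amine would test the amine, and compound 1 gives "not determined" (no result reported), so its open chain with a methyl ester offers no comparison.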